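Phenyl in Place of Hydrogen on the Core of Compound 1

The source may hold more compounds than are shown below. What is called first, only, known or untested is meant among the compounds shown, and "the series" means these compounds.

Compound 1 `O=c1cccnn1CCC(=S)N1CCCC1` is the starting point of this account. In a functional assay on the whole organism (stomach) with Rattus norvegicus as the target (a lower number here means that less compound is needed, a higher number that more compound is needed for the effect), compound 1 gives > 100 mg/kg, and that figure is a limit of the assay rather than a number. Two further compounds also bear a phenyl: compound 2 `N=C(S)CCn1nc(-c2ccccc2)c2ccccc2c1=O` gives 66.5 mg/kg in this assay, and compound 3 `N=C(S)CCCN1N=C(c2ccccc2)CCC1=O` gives 100 mg/kg. The values of compound 2 and compound 3 lie within the usual scatter of each other, so no order between them is drawn. Going by the values given here, no pair of measured compounds that differ in one place is available, and the only evidence on compound 1 is the limit of > 100 mg/kg in this assay, at which 1 of the 3 values shown sits.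

Compound 4 `O=c1ccc(-c2ccccc2)nn1CCC(=S)N1CCCC1` differs from compound 1 by phenyl in place of hydrogen on an aromatic carbon. Among the compounds with values here, no measured step fixes the size of this change. A step toward less compound needed would be in keeping with compound 2 at 66.5 mg/kg and compound 3 at 100 mg/kg, both phenyl-bearing compounds that give numbers. Compound 4 is therefore expected to need about 80 mg/kg, between 40 mg/kg and 160 mg/kg. The step from compound 1 to compound 4 is expected to be an at least 1.2-fold lower number from compound 1 to compound 4 (0.09 log units; that floor lies within the scatter), with a real chance that only a limit is reported again.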

Compound 4, dose for half-maximal effect: > 100 mg/kg
Compound 4 was reported as a limit; the forecaster's own chance of this, stated with the estimate: 40%; middle value at least 1.2-fold (0.09 log units) from the limit.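

In this assay compound 4 gives > 100 mg/kg, which is a limit of the assay and not a number. Compound 1 also stands at a limit, so no step can be read between compound 1 and compound 4. The compounds shown leave open whether phenyl in place of hydrogen on an aromatic carbon changes the dose needed at all, and the evidence on this pair remains: the limit of > 100 mg/kg in this assay, at which 2 of the 4 values shown sit.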